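Chloro in Place of Methoxy on a Nicotinic Receptor Ligand

This account rests on a few compounds, and the source may have more. Where it says the series, first, only, none or still open, it means among the compounds named here.

In an assay for displacement of a labelled ligand from Nicotinic acetylcholine receptor alpha8 subunit (Periplaneta americana), read by scintillation counting, with a stated time of 2 h, at 24 degrees C, tested at 10 uM (on this read-out lower numbers stand for less inhibition and higher numbers for more inhibition at the one concentration tested (going by the name of the read-out)), compound 1 `COc1ccc(/C=C2\CCN=C2c2cccnc2)cc1` gives 31.4%, the lower of the two numbers recorded so far. Compound 2 `COc1ccccc1/C=C1\CCN=C1c1cccnc1` gives 49.5%, a number higher by a margin beyond the usual scatter. Compound 3 `Clc1ccc(/C=C2\CCN=C2c2cccnc2)cc1` differs from compound 1 in one place: chloro in place of methoxy on an aromatic carbon. Going by the values given here, no measured pair shows this change, so the step expected in this assay is small, in either direction, or none beyond the scatter. Compound 3 is therefore expected to give 35%, within 15% to 55%. The step of a number 3.6 percentage points higher from compound 1 to compound 3 (within the scatter) that this estimate means is expected to remain within the scatter.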

Compound 3, a percentage reported as inhibition, at one concentration (the size of the read-out at that concentration, not a potency): 21.5%
Beside the measured number, compound 3's estimate is 13.5 percentage points above it, and the stated range covers the measured number.
By their numbers in this assay, from the lowest: compounds 3 and 1 (each within the scatter of the next); then compound 2.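

In this assay, chloro in place of methoxy on an aromatic carbon, para to a large group, gives the first step measured at this position, a number 9.9 percentage points lower from compound 1 to compound 3 (within the scatter). The step lies within the scatter, so this read-out does not separate chloro from methoxy here, even though the hydrogen-bond acceptor of the methoxy leaves with it. No evidence on the cause of this result is available. From the compounds shown here alone, whether an amine or a carboxylic acid at this place would give a step beyond the scatter stays open. So does whether chloro in place of the methoxy of compound 2 would give a step of similar size.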